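Pyrazolopyrimidine series: fluorobenzyl amine swap on a reduced chain

This account rests on a few compounds, and the source may have more. Where it says the series, first, only, none or still open, it means among the compounds named here.

Compound 1 `CCCc1nn(C)c2c(NC(C)C)nc(/C=C/c3ccc[n+]([O-])c3)nc12` carries an isopropylamino group and the unsaturated linker; in a functional assay on L02 cells (Homo sapiens) for inhibition, read by Griess assay, with stated times of 1 h and 24 h (on this read-out higher numbers stand for weaker inhibition and lower numbers for stronger inhibition), compound 1 gives 324000 nM. Compound 2 `CCCc1nn(C)c2c(NCc3ccc(F)cc3)nc(/C=C/c3ccc[n+]([O-])c3)nc12` keeps the same core and linker. For compound 2 this assay returns only a limit, < 40000 nM. The change between them is 4-fluorobenzyl in place of isopropyl on a nitrogen on an aromatic ring and it makes an at least 8.1-fold lower number from compound 1 to compound 2 (0.90 log units; beyond the scatter); the size of that step can only be bounded, as shown by the limit of < 40000 nM in this assay, at which 1 of the 3 values shown sits.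

Compound 3 `CCCc1nn(C)c2c(NC(C)C)nc(CCc3cccnc3)nc12` has the saturated linker and the pyridine without its oxide; in this assay compound 3 gives 514000 nM. The gap to compound 1 lies within the scatter, so the two values are read as alike. The difference between the core of compound 3 and the core of compound 1 is not broken down here.

Compound 4 `CCCc1nn(C)c2c(NCc3ccc(F)cc3)nc(CCc3cccnc3)nc12` is not yet measured in this assay. It differs from compound 3 by 4-fluorobenzyl in place of isopropyl on a nitrogen on an aromatic ring, the same change as that from compound 1 to compound 2, at the same place. For compound 4 the expected step from its parent is estimated as an 8.6-fold lower number from compound 3 to compound 4 (0.93 log units; beyond the scatter), because the earlier pairing gave an at least 8.1-fold lower number from compound 1 to compound 2 (0.90 log units; beyond the scatter) and the two parents read alike in this assay. The value of compound 4 is therefore estimated at 60000 nM, expected to fall between 20000 nM and 200000 nM, with a real chance that only a limit is reported.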

Compound 4, half-maximal inhibitory concentration: < 40000 nM
Compound 4 was reported as a limit (the forecaster's own chance of this, stated with the estimate: 35%); middle value at least 1.5-fold (0.17 log units) from the limit.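

Carried to the core of compound 3, with its saturated linker and pyridine without the oxide, 4-fluorobenzyl in place of isopropyl gives in this assay an at least 12-fold lower number from compound 3 to compound 4 (1.10 log units; beyond the scatter), so the change points the same way on both cores: the same change on two cores in this assay, an at least 8.1-fold lower number (0.90 log units; beyond the scatter) from compound 1 to compound 2 and an at least 12-fold lower number (1.10 log units; beyond the scatter) from compound 3 to compound 4; the limit leaves it open whether they differ.
Compound 4 is reported only as a limit, < 40000 nM.
The step between compound 2 and compound 4 cannot be read, and the true size of each swap and any difference between the two cores stay unresolved, so the result supports carrying the direction of the change but not a fixed size: the limit of < 40000 nM in this assay, at which 2 of the 4 values shown sit.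

The compounds shown leave open whether the lower numbers need the fluorine or the benzyl group itself, a question that benzyl without the fluorine, 4-chlorobenzyl or a simple cyclopentyl amine would address on either core. They also leave the linker and the pyridine oxide unseparated, since a saturated linker paired with the pyridine oxide, or an unsaturated linker paired with the plain pyridine, does not stand among them, and a longer chain in place of the linker is equally untested here.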